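The compounds below may be only part of what the source reports. "The series", "measured", "known", "first", "only" and "open" are said of these compounds alone.

Of the compounds shown here, three have been measured in a functional assay on CCRF-CEM cells (Homo sapiens) for antiproliferative activity, read by sulforhodamine B assay, with a stated time of 48 h (a lower number here means a stronger inhibitor, a higher number a weaker inhibitor), so far.

- compound 1 `CCc1cccc(NS(=O)(=O)c2ccc(N3CCNC3=O)cc2)c1` gives 200 nM 
- compound 2 `O=C1NCCN1c1ccc(S(=O)(=O)Nc2cccc(Br)c2)cc1` gives 110 nM 
- compound 3 `Cc1cc(C)cc(NS(=O)(=O)c2ccc(N3CCNC3=O)cc2)c1` gives 170 nM 

Compound 3 stands within the scatter of both other compounds, so these numbers do not rank the three. Still unmeasured is compound 4 `Cc1ccc(C)c(NS(=O)(=O)c2ccc(N3CCNC3=O)cc2)c1` which has the same atoms as compound 3 joined differently. The change is 2,5-dimethylphenyl in place of 3,5-dimethylphenyl on a sulfonamide nitrogen and it puts 2,5-dimethylphenyl in place of 3,5-dimethylphenyl on a sulfonamide nitrogen.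

The nearest evidence comes from the measured changes to that same nitrogen substituent. The steps of a 1.8-fold lower number from compound 1 to compound 2 (0.26 log units; within the scatter) and a 1.2-fold lower number from compound 1 to compound 3 (0.07 log units; within the scatter) and a 1.5-fold higher number from compound 2 to compound 3 (0.19 log units; within the scatter) are all small and within the scatter. Going by the values given here, no measured compound carries the 2,5-dimethylphenyl group, so this exact change remains untested, and the range is kept wide. No shift beyond the scatter is therefore expected in this assay in either direction. The estimated step is a 1.2-fold higher number from compound 3 to compound 4 (0.07 log units; within the scatter) and it is expected to stay within the scatter. For compound 4 the expected value is 200 nM with an estimated range from 70 nM to 600 nM as its bounds.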

Compound 4, half-maximal inhibitory concentration: 74 nM
Estimate against measurement, compound 4: 2.7-fold (0.43 log units) above; low and high end bracket the measured number.
By their numbers in this assay, from the lowest: compounds 4, 2, 3 and 1 (each within the scatter of the next, the first and the last beyond it).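

In this assay, going by these compounds alone, 2,5-dimethylphenyl in place of 3,5-dimethylphenyl on the sulfonamide nitrogen gives a 2.3-fold lower number from compound 3 to compound 4 (0.36 log units; beyond the scatter), the first step at this position to lie beyond the scatter, and it comes from rearranging the same atoms. Compound 4 also separates from one other compound, with a 2.7-fold lower number from compound 1 to compound 4 (0.43 log units; beyond the scatter), but not from the bromo compound, with a 1.5-fold lower number from compound 2 to compound 4 (0.17 log units; within the scatter) staying within the scatter, so the change sets compound 4 apart from only two of the three earlier compounds. Nothing given here accounts for this difference between the two dimethylphenyl groups.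

The compounds shown leave open what a methoxy group, an amine or a carboxylic acid would do in place of a methyl group on the 2,5-dimethylphenyl group. On these data alone, all four compounds share the same core, so the effect of a longer chain on that core also remains unknown.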